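The compounds below may be only part of what the source reports. "The series", "measured", "known", "first", "only" and "open" are said of these compounds alone.

In a functional assay (spleen, spleen) for activation, with Mus musculus as the target (a higher number here means that more compound is needed for the effect, a lower number that less compound is needed), compound 1 `Nc1ncnc2c1nc(O)n2Cc1ccc(Cl)cc1` gives 10 uM, and compound 2 `COc1ccc(Cn2c(O)nc3c(N)ncnc32)cc1` gives 10 uM. The step of no change at the digits printed from compound 1 to compound 2 (within the scatter) moved nothing beyond the scatter, so compound 2 stands level with compound 1 on the numbers shown. Compound 3 `Nc1ncnc2c1nc(O)n2Cc1ccc(F)cc1` differs from compound 2 by fluoro in place of methoxy on an aromatic carbon. Among the measured compounds shown here, the only measured step that bears on this change is that exchange of one small group for another on the same aromatic carbon, and it left the reading unchanged, so a step of no change at the digits printed from compound 2 to compound 3 (within the scatter) of no real size is expected. Compound 3 is therefore estimated at 10 uM in this assay, with a range from 3 uM to 30 uM.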

Compound 3, minimum effective concentration: 10 uM
The estimate for compound 3 equals the measured number at the digits printed; the measured number falls inside the stated range.
By their numbers in this assay, from the lowest: compounds 1, 2 and 3 (each within the scatter of the next).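

Fluoro now joins chloro and methoxy on this aromatic carbon, and this assay shows no change at the digits printed from compound 2 to compound 3 (within the scatter) and also no change at the digits printed from compound 1 to compound 3 (within the scatter). Among these three compounds, then, replacing methoxy, which carries a hydrogen-bond acceptor, with fluoro, which carries none, leaves the reading in place. No measured evidence is available to explain this flat result. The compounds shown leave open whether an amine or a carboxylic acid on this aromatic carbon would shift the reading, and whether a longer chain such as butoxy would do so.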